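The source may hold more compounds than are shown below. What is called first, only, known or untested is meant among the compounds shown, and "the series" means these compounds.

Measured compounds in an assay on HEK293 cells for positive allosteric modulation of metabotropic glutamate receptor 2 (Rattus norvegicus), read by thallium flux, with a stated time of 2.5 min; on this read-out higher numbers stand for larger maximal responses and lower numbers for smaller maximal responses:
compound 1 `Cc1c(OCCCCOc2ccc(C(=O)O)cc2)ccc(C(=O)CC(C)C)c1O`: 88%
compound 2 `Cc1c(OCCCCOc2ccc(C(=O)O)cc2)ccc(C(=O)CC2CCCC2)c1O`: 82.6%
compound 3 `CCCC(=O)c1ccc(OCCCCOc2ccc(F)c(C(=O)O)c2)c(C)c1O`: 87.5%

On these numbers compound 2 sits within the scatter of compound 3 and of compound 1; the step of a number 5.4 percentage points lower from compound 1 to compound 2 (within the scatter) is itself within the scatter. Compound 4 `COC(=O)c1ccc(OCCCCOc2ccc(C(=O)CC3CCCC3)c(O)c2C)cc1` is not yet measured in this assay. It differs from compound 2 by methyl in place of hydrogen on an oxygen next to a carbonyl group. Among the measured compounds shown here, no measured step touches this position: the only step recorded, from compound 1 to compound 2, concerns the saturated chain carbon bound to a carbonyl carbon and not the carboxy group, and it stayed within the scatter. There is therefore no basis for expecting a step beyond the scatter in either direction. Compound 4 is estimated at 80% with a range of 65% to 95%. The expected step is a number 2.6 percentage points lower from compound 2 to compound 4 (within the scatter).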

Compound 4, largest response reached (reported as percent of maximum), in percent of the reference or control that the assay uses: 12.2%
Estimate against measurement, compound 4: 67.8 percentage points above; the whole stated range lies above it.
By their numbers in this assay, from the lowest: compound 4; then compounds 2, 3 and 1 (each within the scatter of the next).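

Carboxy to methoxycarbonyl is the first change in this series to move this assay beyond the scatter, with a number 70.4 percentage points lower from compound 2 to compound 4 (beyond the scatter) in a single matched pair. The hydrogen on this oxygen therefore matters to the maximal response here, whereas the change on the saturated chain carbon bound to a carbonyl carbon stayed within the scatter. No measurement available here bears on the reason for this loss.

As far as these compounds go, whether a primary amide or a tetrazole at this place would preserve the response remains open. So does whether methoxycarbonyl would give a similar step on the isopropyl side chain of compound 1.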